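Working notes: extending the alkyl chain on the shared core

The compounds below may be only part of what the source reports. "The series", "measured", "known", "first", "only" and "open" are said of these compounds alone.

Measured so far:
compound 1 `CCc1cc2ccccc2nc1-c1cc(-c2ccc(F)cc2)no1` — > 100000 nM
compound 2 `CCc1cc2ccccc2nc1-c1cc(-c2ccc(C)cc2)no1` — > 100000 nM

In a functional assay on PC-3 cells (Homo sapiens) for inhibition, read by MTT assay, with a stated time of 24 h (on this read-out lower numbers stand for stronger inhibition and higher numbers for weaker inhibition), compound 1 gives > 100000 nM, which is a limit of the assay and not a number. Compound 2, the methyl analogue, gives > 100000 nM in this assay, likewise a limit. The step that the two limits leave unreadable from compound 1 to compound 2 therefore cannot be read. Compound 2 thus stands at the limit, as recorded in the limit of > 100000 nM in this assay, at which 2 of the 2 values shown sit; nothing shown places it anywhere else.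

Compound 3, `CCCCc1cc2ccccc2nc1-c1cc(-c2ccc(C)cc2)no1`, differs from compound 2 by ethyl in place of hydrogen on a saturated chain carbon, two bonds along the chain from an aromatic carbon; read one bond further out, the change is ethyl to butyl. No measured step touches this chain, and the single step shown is unreadable, so no size or direction can be taken from it. Compound 3 is expected to sit at the limit as well, the step that the limit leaves unreadable from compound 2 to compound 3 meaning no readable change. The estimate for compound 3 in this assay is 150000 nM, within 30000 nM to 500000 nM.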

Compound 3, half-maximal inhibitory concentration: > 100000 nM
Compound 3: only a limit was reported (the forecaster's own chance of this, stated with the estimate: 85%); the middle value lies beyond the limit too.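

Compound 3 gives > 100000 nM, which is a limit and not a number, so no step can be read from compound 2 to compound 3. The compounds shown leave open whether the longer chain or the methyl in place of fluoro changes inhibition at all, and no readable value anchors the series: the limit of > 100000 nM in this assay, at which 3 of the 3 values shown sit.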